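The source may report more compounds than this note shows. Statements on the series, on what has been measured and on what is new or still open speak of the compounds shown alone.

In a functional assay on SK-BR-3 cells (Homo sapiens) for antiproliferative activity (on this read-out higher numbers stand for weaker inhibition and lower numbers for stronger inhibition), compound 1 `CC(C)=CCc1cc(C(=O)Nc2cc3ccc(OCCCN(C(C)C)C(C)C)c(C)c3oc2=O)ccc1O` gives (1600 nM), compound 2 `CC(C)=CCc1cc(C(=O)Nc2cc3ccc(OCCCNC(C)(C)C)c(C)c3oc2=O)ccc1O` gives (660 nM) and compound 3 `CC(C)=CCc1cc(C(=O)Nc2cc3ccc(OCCCNC4CCCCC4)c(C)c3oc2=O)ccc1O` gives (660 nM). Compound 3 is thus level with compound 2, and together they hold the lowest number of the three. Compound 4 `CC(C)=CCc1cc(C(=O)Nc2cc3ccc(OCCCNc4ccccc4)c(C)c3oc2=O)ccc1O` differs from compound 3 in one group: phenyl in place of cyclohexyl on an amine nitrogen that is, phenyl in place of cyclohexyl on an amine nitrogen. The measured steps at this same nitrogen are small: a 2.4-fold lower number from compound 1 to compound 2 (0.38 log units; beyond the scatter) and a 2.4-fold lower number from compound 1 to compound 3 (0.38 log units; beyond the scatter) are modest, and no change at the digits printed from compound 2 to compound 3 (within the scatter) is none at all. No aromatic ring on this nitrogen has been measured, so the direction is uncertain, with a slight lean towards a higher number. The expected change is a 1.5-fold higher number from compound 3 to compound 4 (0.18 log units; within the scatter) and would be similarly modest. For compound 4 the estimate is 1000 nM with an expected range from 300 nM to 3000 nM.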

Compound 4, half-maximal inhibitory concentration: > 50000 nM
Compound 4: no number, only a limit; the forecaster's own chance of this, stated with the estimate: 3%; at least 50-fold (1.69 log units) between middle value and limit.
By their numbers in this assay, from the lowest: compounds 2 and 3 (each within the scatter of the next); then compound 1. At a limit, above all of these: compound 4.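

Placing phenyl instead of cyclohexyl on this amine nitrogen, with the carbon count unchanged, gives an at least 75-fold higher number from compound 3 to compound 4 (1.87 log units; beyond the scatter), so this position is far less forgiving than the earlier compounds suggested. Going by these compounds alone, the other two steps run the same way, with an at least 75-fold higher number from compound 2 to compound 4 (1.87 log units; beyond the scatter) and an at least 31-fold higher number from compound 1 to compound 4 (1.49 log units; beyond the scatter), and no earlier step at this nitrogen came close in size. The value of compound 4 is a limit, not a number: the limit of > 50000 nM in this assay, at which 1 of the 4 values shown sits. As far as these compounds go, it remains open whether a benzyl group on this nitrogen would restore the level of compound 3. From the compounds shown here alone, a pyridyl ring in place of phenyl is equally open.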